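The compounds below may be only part of what the source reports. "The series", "measured", "known", "first", "only" and "open" are said of these compounds alone.

Of the compounds shown here, three of a shared core have been measured in a functional assay on MT4 cells (Homo sapiens); on this read-out lower numbers stand for higher toxicity in this test and higher numbers for lower toxicity in this test. Compound 1 `COC(=O)C(=O)CNC1=CS(=O)(=O)O[C@@]12[C@@H](CO[Si](C)(C)C(C)(C)C)O[C@@H](n1cc(C)c(=O)n(C)c1=O)[C@@H]2O[Si](C)(C)C(C)(C)C` gives 10300 nM, compound 2 `Cc1cn([C@@H]2O[C@H](CO[Si](C)(C)C(C)(C)C)[C@@]3(OS(=O)(=O)C=C3NC(N)=O)[C@H]2O[Si](C)(C)C(C)(C)C)c(=O)n(C)c1=O` gives 3700 nM, and compound 3 `Cc1cn([C@@H]2O[C@H](CO[Si](C)(C)C(C)(C)C)[C@@]3(OS(=O)(=O)C=C3NCC(=O)OCc3ccccc3)[C@H]2O[Si](C)(C)C(C)(C)C)c(=O)n(C)c1=O` gives 250000 nM. Compound 3 therefore stands highest of the three, with a 24-fold higher number from compound 1 to compound 3 (1.39 log units; beyond the scatter) and a 68-fold higher number from compound 2 to compound 3 (1.83 log units; beyond the scatter), both well beyond the scatter; by contrast the step of a 2.8-fold lower number from compound 1 to compound 2 (0.44 log units; beyond the scatter) is modest.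

Compound 4 `Cc1cn([C@@H]2O[C@H](CO[Si](C)(C)C(C)(C)C)[C@@]3(OS(=O)(=O)C=C3NCC(=O)O)[C@H]2O[Si](C)(C)C(C)(C)C)c(=O)n(C)c1=O` differs from compound 3 in one place: hydrogen in place of benzyl on an oxygen next to a carbonyl group. Read one bond further out, benzyloxycarbonyl becomes carboxy.

Both large measured steps end in compound 3 and both add the benzyl-bearing group, so they bear on this change even though neither removes benzyl alone. Since a 24-fold higher number from compound 1 to compound 3 (1.39 log units; beyond the scatter) and a 68-fold higher number from compound 2 to compound 3 (1.83 log units; beyond the scatter) both rise sharply on gaining this group, losing it is expected to move the number back down, though how far is uncertain. The step is therefore expected to be a 5.0-fold lower number from compound 3 to compound 4 (0.70 log units; beyond the scatter). For compound 4 the estimate in this assay is 50000 nM, with a range from 12000 nM to 200000 nM.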

Compound 4, half-maximal cytotoxic concentration: 30000 nM
Compound 4: the middle estimate sits 1.7-fold (0.22 log units) above what was measured; the measured number falls inside the stated range.
By their numbers in this assay, from the lowest: compound 2; then compound 1; then compound 4; then compound 3.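

Removing benzyl alone, an 8.3-fold lower number from compound 3 to compound 4 (0.92 log units; beyond the scatter), shows that in this assay the benzyl group accounts for only part of the high number of compound 3. The carboxymethyl group on the amine nitrogen still stands above both other groups without it, with an 8.1-fold higher number from compound 2 to compound 4 (0.91 log units; beyond the scatter) against the carbamoyl compound and a 2.9-fold higher number from compound 1 to compound 4 (0.46 log units; beyond the scatter) against the compound carrying ((methoxycarbonyl)carbonyl)methyl. Nothing measured alongside these numbers explains this order.

Going by these compounds, whether a methyl ester, a primary amide or a longer chain ending in carboxy would fall nearer compound 3 or compound 4 stays open. Also open, on these data alone, is whether the number of compound 3 depends on the aromatic ring of benzyl or would follow from a simple alkyl ester.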